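The source may hold more compounds than are shown below. What is called first, only, known or untested is meant among the compounds shown, and "the series" means these compounds.

Working notes on the series. For the measured compounds named here, compound 1 `CC1(C)CCC(C)(C)c2cc(C(=O)c3ccc(/C=C/C(=O)O)cc3)ccc21` gives 86% in a functional assay for activation of retinoic acid receptor gamma (Homo sapiens) (on this read-out lower numbers stand for smaller maximal responses and higher numbers for larger maximal responses), the higher of the two numbers so far. Compound 2 `Cc1cc(C(=O)c2ccc3c(c2)C(C)(C)CCC3(C)C)ccc1/C=C/C(=O)O` gives 66% in this assay; the step of a number 20 percentage points lower from compound 1 to compound 2 (beyond the scatter) is the only measured one. Compound 3 `C/C(=C\C(=O)O)c1ccc(C(=O)c2ccc3c(c2)C(C)(C)CCC3(C)C)cc1` is not yet measured; the change is 2-carboxy-1-methylethenyl in place of 2-carboxyethenyl on an aromatic carbon. The step from compound 1 to compound 2 bears on it only loosely, since there the methyl enters on an aromatic carbon, whereas here 2-carboxy-1-methylethenyl replaces 2-carboxyethenyl, and that step was modest. For compound 3 at most a small drop is expected, a number 8 percentage points lower from compound 1 to compound 3 (within the scatter). Compound 3 is therefore estimated at 78%, between 55% and 95%.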

Compound 3, largest response reached (reported as maximum), in percent of the reference or control that the assay uses: 51%
Compound 3: middle estimate off by 27 percentage points, on the high side; the measured number lies below the stated range.
By their numbers in this assay, from the lowest: compound 3; then compound 2; then compound 1.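

The 2-carboxyethenyl group, on an aromatic carbon para to a large group, does not take an added methyl without loss: 2-carboxy-1-methylethenyl in its place gives a number 35 percentage points lower from compound 1 to compound 3 (beyond the scatter) in this assay. The chain is thus a second site where a methyl lowers the maximal response, and this step is large, while a number 20 percentage points lower from compound 1 to compound 2 (beyond the scatter) was modest. Nothing available on the compounds accounts for this drop. The compounds shown leave open whether an ethyl or a fluorine on that chain carbon would lower the number as well.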